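A few compounds are considered here, and "the series" means these few. Any claim that something is new, unique, unknown or untested is made for them only; others in the source may bear on it.

Three tertiary amines of the shared core were run in an assay on HEK293 cells for binding affinity to Substance-K receptor (Rattus norvegicus), read by FRET, tested at 10 uM; a higher number here means more inhibition at the concentration tested (going by the name of the read-out), a lower number less inhibition. Compound 1 `N#CCN(Cc1ccc(Br)cc1)Cc1ccc2ccccc2c1` gives 0%. Compound 2 `N#CCCCN(Cc1ccccc1)Cc1ccc2ccccc2c1` gives 0%, and compound 3 `CCCCCCCCCCCCCCCCOC(=O)CN(Cc1ccccc1)Cc1ccc2ccccc2c1` gives 0%. Among the compounds with values here, compound 2 thus stands level with compounds 1 and 3 at the digits reported, both gaps lying within the usual scatter of this assay, and no step between measured compounds can be drawn from these readings. Compound 4 `CCCCNC(=O)CN(Cc1ccccc1)Cc1ccc2ccccc2c1` differs from compound 2 by butylcarbamoyl in place of 2-cyanoethyl on a saturated chain carbon bound to an amine nitrogen. With every measured analogue at the same reading, the expected step is a number 2 percentage points higher from compound 2 to compound 4 (within the scatter), none beyond the scatter in either direction. For compound 4 in this assay the estimate is 2%, ranging from -8% to 12%.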

Compound 4, a percentage reported as inhibition, at one concentration (the size of the read-out at that concentration, not a potency): 0%
Beside the measured number, compound 4's estimate is 2 percentage points above it; the range from low to high includes it.
By their numbers in this assay, from the lowest: compounds 1, 2, 3 and 4 (each within the scatter of the next).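

In this assay, within the data shown here, butylcarbamoyl in place of 2-cyanoethyl on a saturated chain carbon bound to an amine nitrogen gives no change at the digits printed from compound 2 to compound 4 (within the scatter) as the first readable step. An entering group with a hydrogen-bond donor and a larger heavy-atom count thus leaves the reading of compound 4 level with that of compound 2. No measured evidence bears on this result. With every compound shown at the same reading, it remains open whether a carboxylic acid or a primary amine on this chain would give any measurable inhibition in this assay.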